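Shifting the Attachment Point of the Dioxin Group

The compounds below may be only part of what the source reports. "The series", "measured", "known", "first", "only" and "open" are said of these compounds alone.

Compound 2 `O=C(Nc1ccc2ncnc(Nc3cccc(Br)c3)c2c1)C1COc2ccccc2O1` gives 42.9 ug/mL in a functional assay on A-431 cells (Homo sapiens) for antiproliferative activity, read by WST assay, with a stated time of 48 h (a lower number here means a stronger inhibitor, a higher number a weaker inhibitor), the highest number among the three measured compounds. Its nearest neighbour is compound 3 `O=C(Nc1ccc2ncnc(Nc3cccc(Cl)c3)c2c1)C1COc2ccccc2O1`, which gives 19.9 ug/mL; the step of a 2.2-fold lower number from compound 2 to compound 3 (0.33 log units; beyond the scatter) comes from chloro in place of bromo on an aromatic carbon. Compound 1 `Clc1cccc(Nc2ncnc3ccc(NCc4ccc5c(c4)OCCCCO5)cc23)c1` gives 13.3 ug/mL, the lowest of the three. Compound 4 `O=C(Nc1ccc2ncnc(Nc3cccc(Br)c3)c2c1)c1cccc2c1OCCO2` differs from compound 2 by 2,3-dihydro-1,4-benzodioxin-5-yl in place of 2,3-dihydro-1,4-benzodioxin-2-yl on a carbonyl carbon: the same atoms, joined differently, so only the attachment point of the two-ring group changes. Among the measured compounds shown here, no measured step tests such a re-attachment; the single known step, a halogen swap, does not bear on it. The change is therefore expected to give only a small step, a 1.1-fold lower number from compound 2 to compound 4 (0.05 log units; within the scatter). Compound 4 is estimated at 38 ug/mL, within 15 ug/mL to 95 ug/mL.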

Compound 4, half-maximal inhibitory concentration: 20.3 ug/mL
Compound 4: middle estimate off by 1.9-fold (0.27 log units), on the high side; low and high end bracket the measured number.
By their numbers in this assay, from the lowest: compounds 1, 3 and 4 (each within the scatter of the next); then compound 2.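

Joining the same two-ring group to the carbonyl carbon through a different atom gives a 2.1-fold lower number from compound 2 to compound 4 (0.32 log units; beyond the scatter) in this assay. The earlier compounds shown here showed only a halogen swap; this step shows that the attachment point alone can also move the number beyond the scatter. Nothing available explains why this re-attachment has that effect.

Still open, going by these compounds, is whether a phenyl or a morpholine on the same carbonyl carbon would do as well. Also open, on these data alone, is whether chloro in place of bromo would give a similar step alongside 2,3-dihydro-1,4-benzodioxin-5-yl.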